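The compounds below may be only part of what the source reports. "The series", "measured", "known", "first", "only" and "open" are said of these compounds alone.

Measured so far in a functional assay on DU-145 cells (Homo sapiens) for cytotoxicity, read by sulforhodamine B assay, with a stated time of 48 h; a higher number here means a weaker inhibitor, a lower number a stronger inhibitor:
- compound 1 `C[C@H]1CC[C@@H]2[C@@H](OC(=O)[C@]23CC(c2ccccc2)=NO3)[C@]2(C)C(=O)C=C[C@@]12O` at 39800 nM
- compound 2 `C[C@H]1CC[C@@H]2[C@@H](OC(=O)[C@]23CC(c2ccccc2Cl)=NO3)[C@]2(C)C(=O)C=C[C@@]12O` at 19000 nM

Compound 2 holds the lower number of the two. Compound 3 `Cc1ccccc1C1=NO[C@]2(C1)C(=O)O[C@@H]1[C@H]2CC[C@H](C)[C@]2(O)C=CC(=O)[C@@]12C` differs from it in one place (methyl in place of chloro on an aromatic carbon) with methyl in place of chloro on an aromatic carbon. Going by the values given here, the only measured step bearing on this is a 2.1-fold lower number from compound 1 to compound 2 (0.32 log units; beyond the scatter) for chloro in place of hydrogen, a modest one. No measurement compares chloro with methyl directly, so a small rise in the number is expected, perhaps none beyond the scatter. An estimated 1.3-fold higher number from compound 2 to compound 3 (0.12 log units; within the scatter) is what this assay should show. Compound 3 is expected at 25000 nM with 12000 nM to 50000 nM as its estimated range.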

Compound 3, half-maximal inhibitory concentration: 12000 nM
For compound 3 the middle estimate is 2.1-fold (0.32 log units) above the measured one; the range from low to high includes it.
By their numbers in this assay, from the lowest: compounds 3 and 2 (each within the scatter of the next); then compound 1.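

In this assay the step of a 1.6-fold lower number from compound 2 to compound 3 (0.20 log units; within the scatter) shows that methyl and chloro cannot be told apart at this position on the aromatic ring. Set against hydrogen, methyl gives a 3.3-fold lower number from compound 1 to compound 3 (0.52 log units; beyond the scatter) and so, like chloro, stands beyond the scatter, which means that among these three compounds a halogen is not needed for that step. Nothing available explains why either group differs from hydrogen.

On these data alone, whether a methoxy group, an amine or a longer chain such as ethyl would behave like methyl and chloro here remains open. So does the effect of either group elsewhere on the ring.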